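Replacing cyclopropyl on the carbonyl of compound 3

The source may report more compounds than this note shows. Statements on the series, on what has been measured and on what is new or still open speak of the compounds shown alone.

Of the compounds shown here, three sharing one core have been measured in an ADME assay on the whole organism for pharmacokinetics, with Rattus norvegicus as the target; on this read-out lower numbers stand for a shorter-lived compound and higher numbers for a longer-lived compound. Compound 1 `Cc1cc(C)c(NC(=O)c2sccc2S(=O)(=O)Nc2onc(C)c2Cl)c(Cl)c1` gives 2.6 h, compound 2 `CCCS(=O)(=O)c1cc(C)cc(C)c1NC(=O)c1sccc1S(=O)(=O)Nc1onc(C)c1Cl` gives 1.3 h, and compound 3 `Cc1cc(C)c(NC(=O)c2sccc2S(=O)(=O)Nc2onc(C)c2Cl)c(C(=O)C2CC2)c1` gives 5.4 h, the highest of the three numbers. Cyclopropylcarbonyl in place of chloro gave a 2.1-fold higher number from compound 1 to compound 3 (0.32 log units; beyond the scatter), a modest step. Propylsulfonyl in place of chloro gave a 2.0-fold lower number from compound 1 to compound 2 (0.30 log units; within the scatter), which stays within the scatter. The largest step, a 4.2-fold higher number from compound 2 to compound 3 (0.62 log units; beyond the scatter), has cyclopropylcarbonyl in place of propylsulfonyl.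

Compound 4 `Cc1cc(C)c(NC(=O)c2sccc2S(=O)(=O)Nc2onc(C)c2Cl)c(C(=O)CS(C)(=O)=O)c1` keeps the carbonyl of compound 3 and alters the group on it: (methylsulfonyl)methyl in place of cyclopropyl on a carbonyl carbon. Among the compounds with values here, no measured step changes a group on a carbonyl carbon, so the evidence is indirect. Within the data shown here, the nearest guide is compound 2, the only measured compound with a sulfonyl group, which lies a 4.2-fold higher number from compound 2 to compound 3 (0.62 log units; beyond the scatter). Compound 4 keeps the carbonyl as well, so only part of that gap is expected to reappear in this assay. The expected change is a small drop, estimated as a 1.8-fold lower number from compound 3 to compound 4 (0.26 log units; within the scatter). For compound 4 the estimated half-life is 3 h, with an expected range from 1.3 h to 6 h.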

Compound 4, half-life: 12.2 h
Compound 4: the middle estimate sits 4.1-fold (0.61 log units) below what was measured, outside the stated range (above it).
By their numbers in this assay, from the lowest: compounds 2 and 1 (each within the scatter of the next); then compound 3; then compound 4.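

The group on the carbonyl carbon matters in its own right: in this assay, with the carbonyl still attached to the aromatic carbon, (methylsulfonyl)methyl in place of cyclopropyl gives a further rise (a 2.3-fold higher number from compound 3 to compound 4 (0.35 log units; beyond the scatter)). A sulfonyl group at this place does not by itself go with a shorter-lived compound, as compound 2 and compound 4 both carry one, yet the change from propylsulfonyl to ((methylsulfonyl)methyl)carbonyl gives the largest step in the set (a 9.4-fold higher number from compound 2 to compound 4 (0.97 log units; beyond the scatter)), and the same group in place of chloro also raises the number (a 4.7-fold higher number from compound 1 to compound 4 (0.67 log units; beyond the scatter)). No measured property among the data shown accounts for this rise.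

The compounds shown do not separate the sulfonyl group from the chain that carries it, so it remains open whether a methoxymethyl group, a plain methyl or a longer chain ending in a sulfonyl group on the same carbonyl carbon would give a similar half-life. From the compounds shown here alone, it also remains open whether a carboxylic acid or an amine at the end of that chain would keep the number as high as in compound 4.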